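This account rests on a few compounds, and the source may have more. Where it says the series, first, only, none or still open, it means among the compounds named here.

Compound 1, `O=C(CSc1nncnc1-c1cccc2ccccc12)Nc1ccccc1Br`, is tested in an ADME assay on MT4 cells (Homo sapiens) for cytotoxicity, read by MTT assay (on this read-out higher numbers stand for lower toxicity in this test and lower numbers for higher toxicity in this test), where compound 1 gives 87000 nM. Among the measured compounds shown here, that is the highest of the two numbers measured so far; the nearest is compound 2, `NS(=O)(=O)c1ccc(NC(=O)CSc2nncnc2-c2cccc3ccccc23)c(Br)c1`, which gives 23000 nM. For the measured compounds named here, the only measured step, a 3.8-fold lower number from compound 1 to compound 2 (0.58 log units; beyond the scatter), concerns a different group, so it says nothing direct about the change considered now. Compound 3, `O=C(CSc1nncnc1-c1cccc2ccccc12)Nc1ccccc1Cl`, differs from compound 1 in one place: chloro in place of bromo on an aromatic carbon. Going by the values given here, no measured pair here shows bromo swapped for chloro, so the expectation rests only on the closeness of the two groups and on the value of compound 1, 87000 nM. Compound 3 is therefore expected to show no step beyond the scatter, no change at the digits printed from compound 1 to compound 3 (within the scatter). The estimate for compound 3 in this assay is 87000 nM, with a range from 40000 nM to 190000 nM.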

Compound 3, half-maximal cytotoxic concentration: 63000 nM
The estimate for compound 3 lay 1.4-fold (0.14 log units) above the measured number; low and high end bracket the measured number.
By their numbers in this assay, from the lowest: compound 2; then compounds 3 and 1 (each within the scatter of the next).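

In this assay chloro in place of bromo on this aromatic carbon gives a 1.4-fold lower number from compound 1 to compound 3 (0.14 log units; within the scatter) and so, in this test, the two groups cannot be told apart at this place. Among the compounds shown here, this is the first pair that reads on this position itself, since the earlier step concerned sulfamoyl, a different group. Nothing measured on the properties of bromo and chloro is available to explain this result.

With only these two groups compared here, the compounds shown leave open how this assay would read with a group of another kind on this same carbon, such as an amine, a carboxylic acid or a longer chain. They also leave open whether chloro and bromo would still read alike in the presence of sulfamoyl, as carried by compound 2.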